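This account rests on a few compounds, and the source may have more. Where it says the series, first, only, none or still open, it means among the compounds named here.

Compound 1 `COc1cc2nccc(Oc3ccc(Nc4nn(C)cc4C(=O)N4CCCCC4)cc3)c2cc1C(N)=O` gives 5650 nM in a functional assay on BaF3 cells (Mus musculus) for antiproliferative activity, read by CCK-8 assay and cell counting, with a stated time of 76 h; on this read-out higher numbers stand for weaker inhibition and lower numbers for stronger inhibition. Compound 2 `COc1cc2nccc(Oc3ccc(Nc4nn(C)cc4C(=O)NC4CCCCCCC4)cc3)c2cc1C(N)=O` gives 3210 nM in this assay, and the two values stand level, with a 1.8-fold lower number from compound 1 to compound 2 (0.25 log units; within the scatter). Compound 3 `COc1cc2nccc(Oc3ccc(Nc4nn(C)cc4C(=O)NCC4CCCO4)cc3)c2cc1C(N)=O` gives no number, only a limit, > 10000 nM. That limit is reflected in an at least 1.7-fold higher number from compound 1 to compound 3 (0.24 log units; that floor lies within the scatter) and in an at least 3.1-fold higher number from compound 2 to compound 3 (0.49 log units; beyond the scatter).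

Compound 4 `COc1cc2nccc(Oc3ccc(Nc4nn(C)cc4C(=O)N4CCCC5CCCCC54)cc3)c2cc1C(N)=O` keeps the core of compound 1 and changes only the group on a carbonyl carbon: a group of 10 heavy atoms (9 carbon, 1 nitrogen; one six-membered non-aromatic ring of carbon only, one six-membered non-aromatic ring with 1 hetero atom) in place of a group of 6 heavy atoms (5 carbon, 1 nitrogen; one six-membered non-aromatic ring with 1 hetero atom), on a carbonyl carbon. For the measured compounds named here, no measured step makes this exact change. The nearest guide is the replacement of piperidin-1-yl by cyclooctylamino in compound 2, with a 1.8-fold lower number from compound 1 to compound 2 (0.25 log units; within the scatter). Going by the values given here, the only step beyond the scatter, an at least 3.1-fold higher number from compound 2 to compound 3 (0.49 log units; beyond the scatter), brings in the (oxolan-2-yl)methyl group of compound 3, and compound 4 has no such group. No step beyond the scatter is therefore expected in this assay. The expected step is a 1.4-fold lower number from compound 1 to compound 4 (0.15 log units; within the scatter). Compound 4 is estimated at 4000 nM, with an expected range from 1500 nM to 10000 nM.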

Compound 4, half-maximal inhibitory concentration: 4330 nM
Compound 4: the middle estimate sits 1.1-fold (0.03 log units) below what was measured, within the range that was stated.
By their numbers in this assay, from the lowest: compounds 2, 4 and 1 (each within the scatter of the next). At a limit, above all of these: compound 3.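

The group of 10 heavy atoms, which adds a six-membered non-aromatic ring of carbon only, can take the place of piperidin-1-yl on this carbonyl carbon and leave the result in this assay level, with a 1.3-fold lower number from compound 1 to compound 4 (0.12 log units; within the scatter). Compound 4 also stands level with the cyclooctylamino compound, with a 1.3-fold higher number from compound 2 to compound 4 (0.13 log units; within the scatter), so compounds 1, 2 and 4 now form a group of three within the scatter of one another. The (oxolan-2-yl)methyl compound now stands apart from a second compound, with an at least 2.3-fold lower number from compound 3 to compound 4 (0.36 log units; beyond the scatter), although compound 3 gives only a limit: the limit of > 10000 nM in this assay, at which 1 of the 4 values shown sits.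

The compounds shown leave open where a morpholine ring, a piperazine ring or an open hexyl chain on this carbonyl carbon would fall. They also leave open whether any group here can give a step beyond the scatter to a lower number than these three share.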